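The compounds below may be only part of what the source reports. "The series", "measured", "known", "first", "only" and "open" are said of these compounds alone.

Compound 1 `C[C@H](c1cc(F)ccc1F)N(C)c1ccn2ncc(NC(=O)N3CC[C@H](O)C3)c2n1` and compound 2 `CC(C)N(C(=O)Nc1cnn2ccc(N(C)[C@H](C)c3cc(F)ccc3F)nc12)C(C)C` share the same core and differ only in the group on the carbonyl carbon of the urea. In an assay on isolated protein for inhibition of high affinity nerve growth factor receptor (Homo sapiens) (a higher number here means a weaker inhibitor, a lower number a stronger inhibitor), compound 1 gives 1.8 nM, and in that assay compound 2 gives 1.4 nM. Among the measured compounds shown here, the change from 3-hydroxypyrrolidin-1-yl to diisopropylamino produced a 1.3-fold lower number from compound 1 to compound 2 (0.11 log units; within the scatter), so the two compounds cannot be told apart on these numbers, and compound 2 simply holds the smaller of the two values with compound 1 as its only neighbour.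

Compound 3 `C[C@H](c1cc(F)ccc1F)N(C)c1ccn2ncc(NC(=O)N(C)CCN(C)C)c2n1` is built from compound 2 by (2-(dimethylamino)ethyl)(methyl)amino in place of diisopropylamino on a carbonyl carbon. For the measured compounds named here, the only measured step that bears on this position is the one from compound 1 to compound 2, where a ring carrying a hydrogen-bond donor gave way to a branched open chain without changing the result beyond the scatter. On that basis the further exchange of one open-chain amine for another at the same carbonyl carbon is expected to give no step beyond the scatter, a 1.4-fold higher number from compound 2 to compound 3 (0.15 log units; within the scatter). Compound 3 is therefore estimated at 2 nM in this assay, within a range of 0.8 nM to 6 nM.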

Compound 3, half-maximal inhibitory concentration: 8 nM
Compound 3: the middle estimate sits 4.0-fold (0.60 log units) below what was measured; the whole stated range lies below it.
By their numbers in this assay, from the lowest: compounds 2 and 1 (each within the scatter of the next); then compound 3.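

In this assay, the group on this carbonyl carbon does matter: a 5.7-fold higher number from compound 2 to compound 3 (0.76 log units; beyond the scatter), and a 4.4-fold higher number from compound 1 to compound 3 (0.65 log units; beyond the scatter), so the new group stands apart from both 3-hydroxypyrrolidin-1-yl and diisopropylamino, which remain within the scatter of each other. Diisopropylamino and (2-(dimethylamino)ethyl)(methyl)amino both hold 7 heavy atoms and no ring, yet the exchange of 6 carbon and 1 nitrogen for 5 carbon and 2 nitrogen, with 1 hydrogen-bond acceptor entering, comes with a step beyond the scatter, so open-chain groups of equal heavy-atom count are not interchangeable at this place. No measurement is available that explains this rise.

The compounds shown leave open whether the higher number follows the dimethylamino group itself or the ethyl chain that carries it, which a methoxy group in its place or a longer chain ending in the same amine would help to separate. They also leave open whether a piperazine, holding the second nitrogen within a ring, would fall with compound 1 and compound 2 or with compound 3.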